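Working notes: from compound 3 to compound 4

The compounds below may be only part of what the source reports. "The series", "measured", "known", "first", "only" and "open" are said of these compounds alone.

Measured so far in an ADME assay on HUVEC cells (Homo sapiens) for cytotoxicity, read by MTT assay, with a stated time of 72 h; a lower number here means a stronger inhibitor, a higher number a weaker inhibitor:
- compound 1 `COc1cc(-c2nccn2C)cc(OC)c1OC` gives "not determined" (no result reported)
- compound 2 `CCCn1ccnc1-c1cc(OC)c(OC)c(OC)c1` gives "not determined" (no result reported)
- compound 3 `COc1cc(-c2nccn2-c2cccc(C)c2)cc(OC)c1OC` gives > 100000 nM

Compound 3 stands at > 100000 nM in this assay, and this is a limit of the assay, not a number. Within the data shown here, compound 1 and compound 2 have no reported result, so the series offers no single number and no measured step to serve as a guide.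

Compound 4 `COc1ccc(-n2ccnc2-c2cc(OC)c(OC)c(OC)c2)cc1` is the next to be read. It carries 4-methoxyphenyl in place of 3-methylphenyl on an aromatic nitrogen, and the rest of the structure stays the same.

Among the measured compounds shown here, with no measured step available, the size of the change can only be loosely expected. The estimated change is an at least 10-fold lower number from compound 3 to compound 4 (1.00 log units; beyond the scatter), in the direction of a stronger inhibitor, although another limit reading remains possible. For compound 4 the expected value is 10000 nM, with an estimated range from 500 nM to 100000 nM.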

Compound 4, half-maximal inhibitory concentration: > 50000 nM
Compound 4 gave a limit, no number (the forecaster's own chance of this, stated with the estimate: 35%); middle value at least 5.0-fold (0.69 log units) from the limit.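

In this assay compound 3 gives > 100000 nM, a limit and not a number. Compound 4 gives > 50000 nM, also a limit, so no step can be read between compound 3 and compound 4. The compounds shown leave open whether 4-methoxyphenyl in place of 3-methylphenyl on an aromatic nitrogen changes the value at all.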